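Swapping the amide cap: pyridin-2-yl to methyl

This account rests on a few compounds, and the source may have more. Where it says the series, first, only, none or still open, it means among the compounds named here.

Of the compounds shown here, two sharing one core have been tested in a functional assay on the whole organism for inhibition, with Rattus norvegicus as the target, read by cytopathic effect and paw edema, at a dose of 100 mg/kg by the oral route; a lower number here means less inhibition, a higher number more inhibition at the dose given (going by the name of the read-out). Compound 1 `CCOC(=O)c1c(O)c2cccnc2n(-c2ccccc2)c1=O` carries an ethoxy group on its carbonyl carbon and gives 15.5%. Compound 2 `O=C(Nc1ccccn1)c1c(O)c2cccnc2n(-c2ccccc2)c1=O` carries a (pyridin-2-yl)amino group at that position instead and gives 14.6%. Among the compounds with values here, the one measured step, a number 0.9 percentage points lower from compound 1 to compound 2 (within the scatter), shows that exchanging the ester for this amide left the read-out essentially where it was. Within the data shown here, compound 2 thus sits alongside compound 1, its only neighbour, with a gap that falls within the scatter.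

Compound 3 `CNC(=O)c1c(O)c2cccnc2n(-c2ccccc2)c1=O` is the next member: methyl in place of pyridin-2-yl on an amide-type nitrogen. Among the measured compounds shown here, no measured step touches the group on the amide-type nitrogen itself; the only step available, between compound 1 and compound 2, shows no movement beyond the scatter when the whole carbonyl substituent was changed. On that basis the trimming of the pyridin-2-yl to a methyl is expected to produce no step beyond the scatter, meaning a number 0.4 percentage points higher from compound 2 to compound 3 (within the scatter). Compound 3 is therefore estimated to give 15% in this assay, within a range from 4% to 27%.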

Compound 3, a percentage reported as inhibition, in the whole organism at one dose (the size of the read-out at that dose, not a potency): 21%
Compound 3: middle estimate off by 6 percentage points, on the low side, within the range that was stated.
By their numbers in this assay, from the lowest: compounds 2, 1 and 3 (each within the scatter of the next).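

The group on the amide-type nitrogen has now been changed on its own: in this assay, a six-membered aromatic ring gives way to a methyl with no ring, and the step is a number 6.4 percentage points higher from compound 2 to compound 3 (within the scatter). This shows that, at this dose, the read-out does not depend measurably on the pyridin-2-yl ring, since removing it leaves the change within the usual scatter. The methylamino group likewise stands against the ethoxy group of the ester with a number 5.5 percentage points higher from compound 1 to compound 3 (within the scatter), so all three carbonyl substituents remain indistinguishable here, and no available evidence bears on this result.

With every gap inside the scatter, the compounds shown reveal no trend in the size of the group on this nitrogen, and it remains open whether any group placed there could move the read-out clearly, such as a longer chain like n-butyl, a benzyl group or a chain ending in a carboxylic acid. From the compounds shown here alone, it is also open whether these compounds would separate at other doses, as each figure is the size of the effect at one dose and not a potency.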